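Methylating the Selenium of Compound 2

The source may report more compounds than this note shows. Statements on the series, on what has been measured and on what is new or still open speak of the compounds shown alone.

Compound 2 `CSc1ccc(CNc2nc([SeH])nc3ccccc23)cc1` is the only one of the three measured compounds with an actual number in an ADME assay on BEAS-2B cells (Homo sapiens) for cytotoxicity, read by MTT assay, with a stated time of 72 h (a lower number here means a stronger inhibitor of growth, a higher number a weaker inhibitor of growth), where compound 2 gives 58200 nM. Compound 1 `COc1ccc(CNc2nc([Se]C)nc3ccccc23)cc1`, which already carries a methyl on its selenium, reaches only the limit of the assay, > 100000 nM. Compound 3 `[SeH]c1nc(NCc2ccccc2)c2ccccc2n1` likewise stops at a limit, > 100000 nM. Among the measured compounds shown here, the single measured step, an at least 1.7-fold higher number from compound 2 to compound 3 (0.23 log units; that floor lies within the scatter), concerns an aromatic carbon rather than the selenium, so it bears only loosely on the change to compound 4 `CSc1ccc(CNc2nc([Se]C)nc3ccccc23)cc1`, which is methyl in place of hydrogen on a selenium. Because (the limit of > 100000 nM in this assay, at which 2 of the 3 values shown sit), a move toward that limit seems the more likely outcome. Compound 4 is therefore expected to give about 120000 nM, within 40000 nM to 300000 nM. That estimate means a step of a 2.1-fold higher number from compound 2 to compound 4 (0.31 log units; beyond the scatter), a weakening that may not clear the scatter.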

Compound 4, concentration for total growth inhibition: 78500 nM
Estimate against measurement, compound 4: 1.5-fold (0.18 log units) above, and the stated range covers the measured number.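

In this assay, the selenium accepts methyl in place of hydrogen with no readable change, as the step is a 1.3-fold higher number from compound 2 to compound 4 (0.13 log units; within the scatter). Methylsulfanyl in place of methoxy on an aromatic carbon gives only a floor, an at least 1.2-fold lower number from compound 1 to compound 4 (0.10 log units; that floor lies within the scatter). Compound 4 also yields a real number rather than a limit: the limit of > 100000 nM in this assay, at which 2 of the 4 values shown sit.

As far as these compounds go, whether a longer chain or an amine on the selenium would move growth inhibition beyond the scatter remains open. So does whether methyl on the selenium behaves the same way without the methylsulfanyl group.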